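A Methyl Added at the Chain Carbon of Compound 3

The source may hold more compounds than are shown below. What is called first, only, known or untested is meant among the compounds shown, and "the series" means these compounds.

Three compounds sharing one core have so far been run in an ADME assay on microsomes from liver (Rattus norvegicus) for metabolic stability, read by LC-MS; a higher number here means faster removal of the compound, a lower number slower removal. Compound 3, `COc1cc(N2CCN(C(=O)NCc3cccc4ccccc34)CC2)ccc1-c1cnc(C)o1`, shows the highest of the three numbers, giving 160 mL.min-1.g-1 in this assay. Compound 1, `COc1cc(N2CCN(C(=O)N[C@@H](C)c3cccc4ccccc34)CC2)ccc1-n1cnc(C)n1`, gives 110 mL.min-1.g-1, a value within the scatter of that of compound 3, so no order between the two can be claimed. Compound 2, `COc1cc(N2CCN(C(=O)CN3Cc4ccccc4C3)CC2)ccc1-c1cnc(C)o1`, gives 42 mL.min-1.g-1, which lies beyond the scatter below compound 3.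

The next compound, compound 4, `COc1cc(N2CCN(C(=O)N[C@@H](C)c3cccc4ccccc34)CC2)ccc1-c1cnc(C)o1`, has not yet been measured. It differs from compound 3 in one place: methyl in place of hydrogen on a saturated chain carbon bound to an amide-type nitrogen and an aromatic carbon. Within the data shown here, no pair of measured compounds differing only in this way is available, so the size of the step cannot be read from the data. Compound 1, which carries the same methyl on the same chain carbon, and compound 3 differ elsewhere as well, and their two values are within the scatter of each other.

The expectation is therefore a step from compound 3 to compound 4 in this assay of about a 1.2-fold lower number from compound 3 to compound 4 (0.09 log units; within the scatter), not beyond the scatter in either direction. Compound 4 is estimated to give 130 mL.min-1.g-1, with a range from 65 mL.min-1.g-1 to 260 mL.min-1.g-1.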

Compound 4, intrinsic clearance in microsomes: 130 mL.min-1.g-1
Beside the measured number, compound 4's estimate shows no gap at the digits printed, and the stated range covers the measured number.
By their numbers in this assay, from the lowest: compound 2; then compounds 1, 4 and 3 (each within the scatter of the next).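

Among these compounds, with compound 4, methyl in place of hydrogen on a saturated chain carbon bound to an amide-type nitrogen and an aromatic carbon can be read on its own for the first time: in this assay it gives a 1.2-fold lower number from compound 3 to compound 4 (0.09 log units; within the scatter), so at this position the methyl has no effect that can be resolved from the scatter. Among the compounds shown here, compound 4 also gives the first single-place reading of the other group, as 2-methyl-1,3-oxazol-5-yl in place of 3-methyl-1H-1,2,4-triazol-1-yl on an aromatic carbon gives a 1.2-fold higher number from compound 1 to compound 4 (0.07 log units; within the scatter), which accounts for what the earlier comparison of compound 1 and compound 3 could not separate, since those two differ in more than one place. Nothing available bears on why either step is as small as it is.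

From the compounds shown here alone, it remains open how an ethyl or a hydroxymethyl group on the same chain carbon would read in this assay. Also open, going by these compounds, is whether a methyl step of this size would hold with the 3-methyl-1H-1,2,4-triazol-1-yl group in place.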